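Lengthening a Short Chain on the Shared Core

The source may report more compounds than this note shows. Statements on the series, on what has been measured and on what is new or still open speak of the compounds shown alone.

Measured so far:
compound 1 `CCCCSc1nc(N)c2nc(O)n(Cc3ccccc3)c2n1` 0.01 uM
compound 2 `CCNc1nc(N)c2nc(O)n(Cc3ccccc3)c2n1` 1 uM
compound 3 `CCc1nc(N)c2nc(O)n(Cc3ccccc3)c2n1` 1 uM

In a functional assay (spleen, spleen) for activation, with Mus musculus as the target (on this read-out lower numbers stand for an effect already at smaller amounts and higher numbers for an effect only at larger amounts of compound), compound 3 gives 1 uM, level with compound 2 and well behind compound 1, as a 100-fold higher number from compound 1 to compound 3 (2.00 log units; beyond the scatter) shows. Compound 4 `CCCc1nc(N)c2nc(O)n(Cc3ccccc3)c2n1` differs from compound 3 by methyl in place of hydrogen on a saturated chain carbon, two bonds along the chain from an aromatic carbon. Among the measured compounds shown here, no measured step isolates a chain carbon alone: a 100-fold higher number from compound 1 to compound 3 (2.00 log units; beyond the scatter) swaps both the sulfur and the chain length, and no change at the digits printed from compound 2 to compound 3 (within the scatter) touches the chain only at its link to the ring. The only hint is that the longest chain, in compound 1, gave the lowest number. A modest drop is therefore expected, a 3.3-fold lower number from compound 3 to compound 4 (0.52 log units; beyond the scatter), with wide uncertainty, so compound 4 is estimated at 0.3 uM (range 0.05 uM to 2 uM).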

Compound 4, minimum effective concentration: 1 uM
For compound 4 the middle estimate is 3.3-fold (0.52 log units) below the measured one; low and high end bracket the measured number.
By their numbers in this assay, from the lowest: compound 1; then compounds 2, 3 and 4 (each within the scatter of the next).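

Among the compounds shown here, with methyl in place of hydrogen, ethyl becomes propyl, and this assay shows no change at the digits printed from compound 3 to compound 4 (within the scatter) in the only step here that alters chain length alone, so this one added carbon does not move the number. Propyl and ethylamino read alike, showing no change at the digits printed from compound 2 to compound 4 (within the scatter) while butylsulfanyl stays apart, showing a 100-fold higher number from compound 1 to compound 4 (2.00 log units; beyond the scatter) and so going from ethyl to propyl closes none of that gap. No available evidence explains these results.

Going by these compounds, whether the low number of compound 1 belongs to its sulfur or to its chain length remains open. A butyl chain or an ethylsulfanyl group on that aromatic carbon would separate the two.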